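The source may hold more compounds than are shown below. What is called first, only, known or untested is meant among the compounds shown, and "the series" means these compounds.

Compound 1 `COc1cc(Cl)cc(-c2nn(-c3cccc(NC(=O)Nc4ccc(Cl)c(C(F)(F)F)c4)c3)cc2-c2ccncc2)c1`: 31% in a functional assay on SF-295 cells (Homo sapiens) for inhibition, read by sulforhodamine B assay, with a stated time of 48 h, tested at 1 uM; a lower number here means a stronger effect, a higher number a weaker effect of the compound at the concentration tested
Compound 2 `COc1cc(Cl)cc(-c2nn(-c3cccc(NC(=O)Nc4cccc(C(F)(F)F)c4)c3)cc2-c2ccncc2)c1`: 45% in this assay

Among the measured compounds shown here, compound 2 holds the higher of the two numbers in this assay; the only measured step, a number 14 percentage points higher from compound 1 to compound 2 (beyond the scatter), concerns hydrogen in place of chloro on an aromatic carbon. Compound 3 `COc1cc(Cl)cc(-c2nn(-c3cccc(NC(=O)c4cccc(C(F)(F)F)c4)c3)cc2-c2ccncc2)c1` differs from compound 2 by 3-(trifluoromethyl)phenyl in place of (3-(trifluoromethyl)phenyl)amino on a carbonyl carbon. For the measured compounds named here, no measured step touches this kind of change, so the expectation rests on the value of compound 2 alone and is uncertain. Compound 3 is expected to give about 55%, in the range 35% to 80%. The step of a number 10 percentage points higher from compound 2 to compound 3 (within the scatter) is thus expected to be modest, with the direction open.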

Compound 3, a percentage reported as activity, at one concentration (the size of the read-out at that concentration, not a potency): 57%
Compound 3: middle estimate off by 2 percentage points, on the low side, and the stated range covers the measured number.
By their numbers in this assay, from the lowest: compound 1; then compound 2; then compound 3.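

Losing the amino nitrogen on the carbonyl carbon, and with it a hydrogen-bond donor, weakens the effect in this assay (a number 12 percentage points higher from compound 2 to compound 3 (beyond the scatter)), so this position is sensitive to more than the chloro group seen earlier. Combined with the loss of that chloro, the change gives the largest gap among these compounds (a number 26 percentage points higher from compound 1 to compound 3 (beyond the scatter)). Nothing here explains either step.

As far as these compounds go, what stays open is whether the nitrogen itself matters, since a methylene or an ether oxygen in its place could separate its presence from the spacing it provides. From the compounds shown here alone, whether chloro would help the compound 3 series equally also remains unknown.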